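Changing the Indole to an Indoline in a Solubility Series

The source may report more compounds than this note shows. Statements on the series, on what has been measured and on what is new or still open speak of the compounds shown alone.

Compound 1 `CNC(=O)c1cc(C(=O)NC2CC2)cn(Cc2cccc3[nH]c(C)nc23)c1=O` and compound 2 `CNC(=O)c1cc(C(=O)NC2CC2)cn(Cc2cccc3cc[nH]c23)c1=O` share one core and differ only in the group on a saturated chain carbon bound to an aromatic nitrogen. In a physicochemical assay for solubility (a higher number here means a more soluble compound, a lower number a less soluble compound), compound 1 gives >= 198 ug/mL, which is a limit of the measurement rather than a number. In this assay compound 2 gives >= 144 ug/mL, again a limit (the limit of >= 144 ug/mL in this assay, at which 1 of the 2 values shown sits). Compound 3 `CNC(=O)c1cc(C(=O)NC2CC2)cn(Cc2cccc3c2CCN3)c1=O` carries 2,3-dihydro-1H-indol-4-yl in place of 1H-indol-7-yl on a saturated chain carbon bound to an aromatic nitrogen. The step that the limit leaves unreadable from compound 2 to compound 3 is what is expected in this assay, nothing beyond the usual scatter. Compound 3 is expected to reach about 200 ug/mL in this assay, somewhere between 100 ug/mL and 400 ug/mL.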

Compound 3, solubility: >= 184 ug/mL
Compound 3: no number, only a limit (the forecaster's own chance of this, stated with the estimate: 70%); the middle value does not contradict the limit.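

Compound 2 and compound 3 each give only a limit in this assay, and the step between them cannot be read. The true solubility of these compounds, and any real difference between 1H-indol-7-yl and 2,3-dihydro-1H-indol-4-yl, stay open.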